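Cytotoxicity notes on the series: trimming the fused quinone portion

The compounds below may be only part of what the source reports. "The series", "measured", "known", "first", "only" and "open" are said of these compounds alone.

Compound 1 `COc1ccc(N/C(CCNC2=CC(=O)c3ccccc3C2=O)=N\S(=O)(=O)c2ccc(C)cc2)cc1OC` is the reference of this set. For the measured compounds named here, in an ADME assay on HEK293 cells (Homo sapiens) for cytotoxicity, read by MTT assay, with a stated time of 48 h (on this read-out lower numbers stand for stronger inhibition and higher numbers for weaker inhibition), compound 1 gives 60600 nM, the lowest of the two numbers measured so far. Compound 2 `COc1ccc(N/C(CCNC2=CC(=O)c3ccccc3C2=O)=N\S(=O)(=O)c2ccc(C)cc2)c(OC)c1` is its nearest neighbour; in this assay compound 2 gives 83000 nM. Going by the values given here, the only measured step, a 1.4-fold higher number from compound 1 to compound 2 (0.14 log units; within the scatter), exchanges the 2,4-dimethoxyphenyl for the 3,4-dimethoxyphenyl on an amine nitrogen and stays within the scatter.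

Compound 3 `COc1ccc(N/C(CCNC2=CC(=O)C(C)=C(C)C2=O)=N\S(=O)(=O)c2ccc(C)cc2)cc1OC` is not yet measured. Relative to compound 1 the change is a group of 10 heavy atoms (8 carbon, 2 oxygen; one six-membered non-aromatic ring of carbon only) in place of a group of 12 heavy atoms (10 carbon, 2 oxygen; one six-membered non-aromatic ring of carbon only, one six-membered aromatic ring of carbon only), on an amine nitrogen; the dimethoxyphenyl part and the sulfonyl part are kept. Among the compounds with values here, no measured step touches this position of the shared core, so the step from compound 1 to compound 2 does not speak to it directly; it only shows that the series as a whole sits at high concentrations in this assay. Within the data shown here, with no precedent for the change, a step of modest size in either direction is plausible, and none beyond the scatter is the default expectation.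

Compound 3 is therefore expected to give about 70000 nM in this assay, within a range from 25000 nM to 200000 nM, which corresponds to an expected step of a 1.2-fold higher number from compound 1 to compound 3 (0.06 log units; within the scatter).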

Compound 3, half-maximal inhibitory concentration: 79400 nM
Estimate against measurement, compound 3: 1.1-fold (0.05 log units) below; measured number inside the range.
By their numbers in this assay, from the lowest: compounds 1, 3 and 2 (each within the scatter of the next).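

In this assay, for the compounds shown here, the group of 10 heavy atoms in place of the group of 12 heavy atoms on the amine nitrogen gives a 1.3-fold higher number from compound 1 to compound 3 (0.12 log units; within the scatter), the first measured step at this position of the shared core. The entering group lacks the six-membered aromatic ring of carbon only and carries 4 double bonds outside aromatic rings against 3, yet compound 1 and compound 3 cannot be told apart in this read-out, so this exchange shows no effect beyond the scatter for this pair. Nothing at hand offers an explanation for how closely the two compounds read.

Still open, from the compounds shown here alone, is whether a group of a different kind on this amine nitrogen, such as a carboxylic acid or a longer chain, would give a step beyond the scatter in this assay. Also open is whether the same exchange would read alike with the 2,4-dimethoxyphenyl in place of the 3,4-dimethoxyphenyl, since the shown pair covers only the 3,4-dimethoxyphenyl form.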